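The source may hold more compounds than are shown below. What is called first, only, known or untested is meant among the compounds shown, and "the series" means these compounds.

Compound 1 `Cc1n[nH]cc1-c1cccc2c1CCC2c1ncc[nH]1`: 3 nM in a functional assay on CHO cells for agonist activity at Alpha-1A adrenergic receptor (Homo sapiens), read by FLIPR and calcium flux; on this read-out lower numbers stand for an effect already at smaller amounts and higher numbers for an effect only at larger amounts of compound.
Compound 2 `Cn1nccc1-c1cccc2c1CCC2c1ncc[nH]1`: 278 nM in this assay.

Within the data shown here, only two compounds carry numbers so far. Among the measured compounds shown here, compound 2 stands at the higher of the two, and the only measured step, a 93-fold higher number from compound 1 to compound 2 (1.97 log units; beyond the scatter), separates them. Compound 3 `c1cncc(-c2cccc3c2CCC3c2ncc[nH]2)c1` has not yet been measured. It differs from compound 2 in one place: pyridin-3-yl in place of 1-methyl-1H-pyrazol-5-yl on an aromatic carbon. For the measured compounds named here, no measured pair shows this particular exchange, so nothing fixes its direction. Going by the values given here, the one step that bears on it, a 93-fold higher number from compound 1 to compound 2 (1.97 log units; beyond the scatter), shows that exchanging the aromatic group at this position can move the number a long way while the shared core stays the same. Among the compounds with values here, with compound 2 at 278 nM and the only other number far lower, a move in either direction remains possible. The expected step is a 4.6-fold lower number from compound 2 to compound 3 (0.67 log units; beyond the scatter), leaning downward but with wide uncertainty. Compound 3 is therefore expected to give about 60 nM in this assay, between 6 nM and 600 nM.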

Compound 3, half-maximal effective concentration: 2060 nM
Compound 3: the middle estimate sits 34-fold (1.54 log units) below what was measured; the measured number lies above the stated range.
By their numbers in this assay, from the lowest: compound 1; then compound 2; then compound 3.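

In this assay, pyridin-3-yl in place of 1-methyl-1H-pyrazol-5-yl on this aromatic carbon gives a 7.4-fold higher number from compound 2 to compound 3 (0.87 log units; beyond the scatter), so moving from a five-membered to a six-membered aromatic ring here does not bring the number back down. Set against 3-methyl-1H-pyrazol-4-yl, the same pyridin-3-yl gives a 690-fold higher number from compound 1 to compound 3 (2.84 log units; beyond the scatter), the widest gap among the three compounds. Among these compounds, the shared core stays the same throughout, and of these three groups, 3-methyl-1H-pyrazol-4-yl remains the one with the lowest number.

Nothing given here explains these differences. Also open, from the compounds shown here alone, is where a plain phenyl ring or a 1H-pyrazol-4-yl without its methyl group would fall on this carbon, which would help show whether the methyl group or the ring itself matters more.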